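The source may hold more compounds than are shown below. What is called first, only, known or untested is meant among the compounds shown, and "the series" means these compounds.

The measured compounds:
Compound 1 `CC1(C)[C@@H]2CC[C@@]1(C)/C(=N/NC(=O)c1cccs1)C2`, in an ADME assay on Vero cells (Chlorocebus sabaeus) for cytotoxicity, read by spectrophotometry, with a stated time of 4 days; on this read-out higher numbers stand for lower toxicity in this test and lower numbers for higher toxicity in this test: 363000 nM.
Compound 3 `CC12C=CC3(O1)C(C(=O)N1c4ccccc4SC13)C2C(=O)N/N=C1\C[C@H]2CC[C@]1(C)C2(C)C`, in this assay: 67200 nM.
Compound 2 `CC1(C)[C@@H]2CC[C@@]1(C)/C(=N/NC(=O)C(F)(F)F)C2`, in this assay: > 250000 nM, a limit of the assay and not a number.

Among the two numbers, compound 1 stands highest, and compound 3 sits lower by a gap beyond the scatter. The step that the limit leaves unreadable from compound 1 to compound 2 cannot be sized because of the limit of > 250000 nM in this assay, at which 1 of the 3 values shown sits.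

Compound 4 `CC1(C)[C@@H]2CC[C@@]1(C)/C(=N/NC(=O)c1ccc(Br)cc1)C2` differs from compound 1 in one place: 4-bromophenyl in place of thiophen-2-yl on a carbonyl carbon. For the measured compounds named here, the only measured step at that place, from compound 1 to compound 2, is unreadable, so no step is known that bears on the change to compound 4. In this assay, compound 4 is therefore expected to give a number close to that of compound 1, with the step of a 1.5-fold lower number from compound 1 to compound 4 (0.16 log units; within the scatter) estimated to lie within the scatter. The estimate for compound 4 is 250000 nM, with a range from 90000 nM to 600000 nM.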

Compound 4, half-maximal cytotoxic concentration: 288000 nM
For compound 4 the middle estimate is 1.2-fold (0.06 log units) below the measured one; measured number inside the range.
By their numbers in this assay, from the lowest: compound 3; then compounds 4 and 1 (each within the scatter of the next).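

In this assay, the place on the carbonyl carbon now gives its first readable step, a 1.3-fold lower number from compound 1 to compound 4 (0.10 log units; within the scatter). So thiophen-2-yl, a five-membered aromatic ring with 1 hetero atom, and 4-bromophenyl, a six-membered aromatic ring of carbon only, cannot be told apart in this test, at least for this one pair on the shared core. The steps involving compound 2 still cannot be read, because its value is a limit of the assay and not a number: the limit of > 250000 nM in this assay, at which 1 of the 4 values shown sits.

On these data alone, whether an amine, a carboxylic acid or a longer alkyl chain on the same carbonyl carbon would keep the number within the scatter of compound 1 remains open. Also open, as far as these compounds go, is whether a chlorine or a methoxy group in place of the bromine would change the number.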